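Carboxy in place of cyano on the aryl ketone

A few compounds are considered here, and "the series" means these few. Any claim that something is new, unique, unknown or untested is made for them only; others in the source may bear on it.

Compound 1 `O=C(/C(=C\c1ccc(O)c([N+](=O)[O-])c1)SCc1ccc(Br)cc1)c1ccc(O)cc1O` — in a functional assay on DU-145 cells (Homo sapiens) for inhibition, read by trypan blue exclusion, with a stated time of 96 h (a lower number here means a stronger inhibitor of growth, a higher number a weaker inhibitor of growth), compound 1 gives only a limit, > 100000 nM.
Compound 2 `N#Cc1ccc(C(=O)/C(=C\c2ccc(O)c([N+](=O)[O-])c2)SCc2ccc(Br)cc2)cc1` — in this assay compound 2 gives 10000 nM.

Compound 2 holds the only number shown in this assay; the other value is a limit, (the limit of > 100000 nM in this assay, at which 1 of the 2 values shown sits). Among the compounds with values here, the step of an at least 10-fold lower number from compound 1 to compound 2 (1.00 log units; beyond the scatter) is the single measured step, and it concerns the group on the carbonyl carbon, not the substituent now at issue.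

Compound 3 `O=C(O)c1ccc(C(=O)/C(=C\c2ccc(O)c([N+](=O)[O-])c2)SCc2ccc(Br)cc2)cc1` differs from compound 2 by carboxy in place of cyano on an aromatic carbon. No measured step touches this change, so nothing shown supports a shift in either direction beyond the scatter. The account therefore expects compound 3 to stay near compound 2, with the step of a 2.0-fold higher number from compound 2 to compound 3 (0.30 log units; within the scatter) treated as no more than scatter. The estimate for compound 3 in this assay is 20000 nM, within 5000 nM to 100000 nM.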

Compound 3, concentration for 50% growth inhibition: 50000 nM
The estimate for compound 3 lay 2.5-fold (0.40 log units) below the measured number; the range from low to high includes it.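

In this assay, within the data shown here, this position on the aryl ketone proves sensitive to the group it carries: carboxy in place of cyano gives a 5.0-fold higher number from compound 2 to compound 3 (0.70 log units; beyond the scatter), the first measured step at this substituent. Set against the 2,4-dihydroxyphenyl group, the 4-carboxyphenyl group gives an at least 2.0-fold lower number from compound 1 to compound 3 (0.30 log units; that floor lies within the scatter), a floor that does not by itself separate the two groups. That step remains only a floor because compound 1 gives a limit rather than a number: the limit of > 100000 nM in this assay, at which 1 of the 3 values shown sits.

The compounds shown leave open how an amine, an amide or a methyl ester would compare with the nitrile and the carboxylic acid at this place, para to a large group. They also leave open whether the step from cyano to carboxy would hold with a different group in place of the 4-bromobenzyl group on sulfur.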